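The source may report more compounds than this note shows. Statements on the series, on what has been measured and on what is new or still open speak of the compounds shown alone.

Compound 1, whose structure is `Nc1nc(C(F)(F)F)cc2c1[nH]c(=O)n2Cc1ccc(NCCO)nc1`, gives 1.6 in a physicochemical assay for lipophilicity; on this read-out higher numbers stand for higher lipophilicity and lower numbers for lower lipophilicity. Among the three measured compounds it stands second highest. Compound 2, `Nc1nc(C(F)(F)F)cc2c1[nH]c(=O)n2Cc1ccc(NCc2ccccc2)nc1`, gives 1.8, and the step of a number 0.20 log units higher from compound 1 to compound 2 (within the scatter). Compound 3, `CN(C)CCN(C)c1ccc(Cn2c(=O)[nH]c3c(N)nc(C(F)(F)F)cc32)cn1`, gives 1.2; the step of a number 0.40 log units lower from compound 1 to compound 3 (beyond the scatter), and the step of a number 0.60 log units lower from compound 2 to compound 3 (beyond the scatter).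

Compound 4, `CN(C)CCN1CCN(c2ccc(Cn3c(=O)[nH]c4c(N)nc(C(F)(F)F)cc43)cn2)CC1`, is not yet measured. Its structure differs from compound 1 in one place: 4-(2-(dimethylamino)ethyl)piperazin-1-yl in place of (2-hydroxyethyl)amino on an aromatic carbon. Within the data shown here, the step that bears most on this change is the one from compound 1 to compound 3, where a (2-(dimethylamino)ethyl)(methyl)amino group also replaced the (2-hydroxyethyl)amino group and lowered this assay by a modest amount. The 4-(2-(dimethylamino)ethyl)piperazin-1-yl group brings a larger ring-containing group with the same dimethylaminoethyl chain, so a modest lowering is expected again, a number 0.40 log units lower from compound 1 to compound 4 (beyond the scatter). For compound 4 the value is estimated at 1.2, within a range from 0.7 to 1.7.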

Compound 4, distribution coefficient: 0.9
Compound 4: middle estimate off by 0.30 log units, on the high side; the range from low to high includes it.
By their numbers in this assay, from the lowest: compounds 4 and 3 (each within the scatter of the next); then compounds 1 and 2 (each within the scatter of the next).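

On the aromatic carbon next to the ring nitrogen, this assay gives a step of a number 0.70 log units lower from compound 1 to compound 4 (beyond the scatter) when 4-(2-(dimethylamino)ethyl)piperazin-1-yl replaces (2-hydroxyethyl)amino and a step of a number 0.90 log units lower from compound 2 to compound 4 (beyond the scatter) when it replaces benzylamino. The step of a number 0.30 log units lower from compound 3 to compound 4 (within the scatter) leaves compound 3 and compound 4 not separated on this read-out, so adding the six-membered non-aromatic ring does not set compound 4 apart, and the two compounds carrying the dimethylaminoethyl chain both stand clear of compound 1 and compound 2, with none of the four going against this. No supporting measurement is available to explain these steps.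

From the compounds shown here alone, whether the shift follows the dimethylamino end of the chain or something else in these groups remains open. A morpholine ring, or a piperazine bearing a 2-hydroxyethyl chain, on the same carbon would help separate these possibilities.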